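Bromo for fluoro on a full agonist series

The compounds below may be only part of what the source reports. "The series", "measured", "known", "first", "only" and "open" are said of these compounds alone.

Three compounds, each built on a shared core that carries an imidazole-bearing chain and a pyridine-bearing chain, were measured in a functional assay on cardiac atrium for agonist activity at histamine H2 receptor (Cavia porcellus); a lower number here means a smaller maximal response, a higher number a larger maximal response. Compound 1 `N=C(NCCCc1c[nH]cn1)NCCCC(c1ccccc1)c1ccccn1` gives 1 in this assay. Compound 2 `COc1ccc(C(CC/N=C(\N)NCCCc2c[nH]cn2)c2ccccn2)cc1` gives 1 in this assay. Compound 3 `N=C(NCCCc1c[nH]cn1)NCCC(c1ccc(F)cc1)c1ccccn1` gives 1 in this assay. Compound 3 therefore stands level with compound 1 and with compound 2 at the digits shown; the gaps to both lie within the scatter of such measurements, so no ordering among the three can be read from the numbers.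

Compound 4 `N=C(NCCCc1c[nH]cn1)NCCC(c1ccc(Br)cc1)c1ccccn1` has not yet been measured in this assay. It differs from compound 3 in one place: bromo in place of fluoro on an aromatic carbon.

Since compound 1, compound 2 and compound 3 all reach the full response of the reference agonist, and the change from compound 3 to compound 4 exchanges one halogen for another on the same aromatic carbon, the expected step of no change at the digits printed from compound 3 to compound 4 (within the scatter) is none beyond the scatter. Compound 4 is accordingly expected to give about 1 in this assay, within a range from 0.9 to 1.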

Compound 4, intrinsic activity: the largest response reached, as a fraction of the reference agonist's: 1
The estimate for compound 4 equals the measured number at the digits printed; the range from low to high includes it.
By their numbers in this assay, from the lowest: compounds 1, 2, 3 and 4 (each within the scatter of the next).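

For the compounds shown here, the exchange of 4-fluorophenyl for 4-bromophenyl gives the only step here between two compounds that differ in one place: in this assay there is no change at the digits printed from compound 3 to compound 4 (within the scatter), and the earlier compounds could only be set side by side. It shows that on this aromatic carbon, para to a large group, bromo can stand in place of fluoro without a change in the largest response that can be read at the digits printed. No measurement shown here offers an explanation for this result.

The read-out gives only the largest response reached, so the compounds leave open how much of compound 3 or compound 4 is needed to reach it, and whether the two differ in that respect. Going by these compounds alone, it also remains open whether the response would hold with an amine, a carboxylic acid or a nitrile on the same aromatic carbon, since halogens are the only groups compared directly at this position.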